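Exchanging the Amino Acid Tail of Compound 2

The source may hold more compounds than are shown below. What is called first, only, known or untested is meant among the compounds shown, and "the series" means these compounds.

In a functional assay on PC-12 cells (Rattus norvegicus) for inhibition, read by MTT assay (on this read-out lower numbers stand for an effect already at smaller amounts and higher numbers for an effect only at larger amounts of compound), compound 2 `CC1(C)N(O)C(c2ccc(OCC(=O)NCCCC[C@H](N)C(=O)O)cc2)=[N+]([O-])C1(C)C` gives 90600 nM. Compound 1 `CC1(C)N(O)C(c2ccc(OCC(=O)N[C@@H](CCCCN)C(=O)O)cc2)=[N+]([O-])C1(C)C` gives 90600 nM and compound 3 `CC(C)(C)OC(=O)N[C@@H](CCCCNC(=O)COc1ccc(C2=[N+]([O-])C(C)(C)C(C)(C)N2O)cc1)C(=O)O` gives 89900 nM, so compound 2 stands level with compound 1, the two sharing the highest numbers of the three, with compound 3 close behind. Compound 4 `CC1(C)N(O)C(c2ccc(OCC(=O)N[C@@H](CCCNC(=N)N)C(=O)O)cc2)=[N+]([O-])C1(C)C` differs from compound 2 by a group of 11 heavy atoms (6 carbon, 3 nitrogen, 2 oxygen; no ring) in place of a group of 9 heavy atoms (6 carbon, 1 nitrogen, 2 oxygen; no ring), on an amide-type nitrogen. Within the data shown here, two measured steps touch the same part of the molecule: no change at the digits printed from compound 1 to compound 2 (within the scatter) and a 1.0-fold lower number from compound 2 to compound 3 (0.00 log units; within the scatter). Neither of them shifted the number beyond the scatter, so this further exchange of the tail on that nitrogen is expected to leave this assay roughly where it is, a step of a 1.0-fold lower number from compound 2 to compound 4 (0.00 log units; within the scatter). Compound 4 is therefore estimated at 90000 nM, within a range from 45000 nM to 180000 nM.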

Compound 4, half-maximal effective concentration: 92900 nM
For compound 4 the middle estimate is 1.0-fold (0.01 log units) below the measured one, within the range that was stated.
By their numbers in this assay, from the lowest: compounds 3, 1, 2 and 4 (each within the scatter of the next).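

In this assay, a larger tail on the amide-type nitrogen, with more hydrogen-bond donors, still leaves the number within the scatter: a 1.0-fold higher number from compound 2 to compound 4 (0.01 log units; within the scatter). Changing only the end of the saturated chain gives the same picture: a 1.0-fold higher number from compound 1 to compound 4 (0.01 log units; within the scatter). So a different amino acid tail, and not only a rearranged or capped one, leaves this read-out in place, and no available evidence bears on this result. Still open, going by these compounds, is whether a tail that carries a phenyl ring, or a methyl ester in place of the carboxylic acid, would shift the number beyond the scatter.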